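The compounds below may be only part of what the source reports. "The series", "measured", "known", "first", "only" and "open" are said of these compounds alone.

Three compounds built on a shared core have been examined in a functional assay on DU-145 cells (Homo sapiens) for inhibition, read by trypan blue exclusion, with a stated time of 72 h; on this read-out higher numbers stand for weaker inhibition and lower numbers for stronger inhibition. Compound 1 `O=c1c(S(=O)(=O)c2ccc(F)cc2F)cc2cnc(Nc3ccc4[nH]ccc4c3)nc2n1C1CC1` gives 500 nM. Compound 2 `CCCn1c(=O)c(S(=O)(=O)c2ccc(F)cc2F)cc2cnc(Nc3ccc4[nH]ccc4c3)nc21` gives 1000 nM, and compound 3 `O=c1c(S(=O)(=O)c2ccc(F)cc2F)cc2cnc(Nc3ccc4[nH]ccc4c3)nc2n1CC1CC1` gives 1000 nM. All three differ only in the group on the aromatic nitrogen of the core, and the steps among them are small: a 2.0-fold higher number from compound 1 to compound 2 (0.30 log units; within the scatter), a 2.0-fold higher number from compound 1 to compound 3 (0.30 log units; within the scatter), and no change at the digits printed from compound 2 to compound 3 (within the scatter). On these numbers compound 3 stands level with compound 2, the two together holding the highest number of the three, with compound 1 furthest away.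

Compound 4 `O=c1[nH]c2nc(Nc3ccc4[nH]ccc4c3)ncc2cc1S(=O)(=O)c1ccc(F)cc1F` goes one step beyond: hydrogen in place of cyclopropylmethyl on an aromatic nitrogen. The three measured steps all bear on the same aromatic nitrogen, and each stayed within the scatter, which suggests that this position tolerates a range of groups. None of them, however, removed the group altogether, so the step to a bare hydrogen lies outside the range actually tested. On that basis no step beyond the scatter is expected in this assay, though the uncertainty is wider than for the measured pairs. Compound 4 is therefore estimated at 1200 nM, with a range from 400 nM to 4000 nM, corresponding to an expected step of a 1.2-fold higher number from compound 3 to compound 4 (0.08 log units; within the scatter).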

Compound 4, half-maximal inhibitory concentration: 15000 nM
The estimate for compound 4 lay 13-fold (1.10 log units) below the measured number; the whole stated range lies below it.
By their numbers in this assay, from the lowest: compounds 1, 2 and 3 (each within the scatter of the next); then compound 4.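

In this assay, within the data shown here, the aromatic nitrogen of the shared core proves less forgiving than the earlier compounds suggested, since the change to a bare hydrogen gives large steps from all three substituted compounds: a 15-fold higher number from compound 3 to compound 4 (1.18 log units; beyond the scatter) with hydrogen in place of cyclopropylmethyl, a 15-fold higher number from compound 2 to compound 4 (1.18 log units; beyond the scatter) with hydrogen in place of propyl, and a 30-fold higher number from compound 1 to compound 4 (1.48 log units; beyond the scatter) with hydrogen in place of cyclopropyl. The tolerance seen at this position therefore holds among the cyclopropyl, propyl and cyclopropylmethyl groups, which stay within the scatter of one another, but it does not extend to removing the group altogether, and compound 4 is the only one of the four that departs from the others beyond the scatter. Nothing available here explains why this change has so large an effect on the read-out.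

The compounds shown leave open whether a small group such as methyl or ethyl on this nitrogen would stay with compounds 1, 2 and 3 or fall nearer compound 4. They also leave open how far the tolerance reaches in the other direction, for instance with a longer chain, a benzyl group or a chain ending in an amine.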